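Swapping the aryl group on a urea nitrogen

A few compounds are considered here, and "the series" means these few. Any claim that something is new, unique, unknown or untested is made for them only; others in the source may bear on it.

Measured in an ADME assay on Raji cells (Homo sapiens) for cytotoxicity, with a stated time of 72 h; a lower number here means that less compound is needed, a higher number that more compound is needed for the effect:
Compound 1 `Cc1cc(NC(=O)Nc2ccccc2N)c2ccccc2n1`: > 25000 nM, a limit of the assay
Compound 2 `Cc1cc(NC(=O)Nc2ccc(F)cc2)c2ccccc2n1`: > 25000 nM, a limit of the assay
Compound 3 `Cc1cc(NC(=O)Nc2ccc(C(F)(F)F)cc2)c2ccccc2n1`: 23000 nM

In this assay compound 2 gives > 25000 nM, which is a limit and not a number. It sits at the limit of > 25000 nM in this assay, at which 2 of the 3 values shown sit. Compound 4 `Cc1cc(NC(=O)Nc2ncccc2C)c2ccccc2n1` is reached from compound 2 by this change: 3-methylpyridin-2-yl in place of 4-fluorophenyl on an amide-type nitrogen. In words, 3-methylpyridin-2-yl stands in place of 4-fluorophenyl on an amide-type nitrogen.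

Going by the values given here, two measured steps bear on this. The one at the same place is a step that the two limits leave unreadable from compound 1 to compound 2. The other, an at least 1.0-fold lower number from compound 2 to compound 3 (0.03 log units; that floor lies within the scatter), alters the aromatic group on that nitrogen. Neither shows a move beyond the scatter, so no direction can be drawn from them. The expected outcome is a number no higher from compound 2 to compound 4 (the limit leaves the size open), with no change beyond the scatter anticipated in this assay, and a reading at the limit is likely.

For compound 4 the estimated value is 25000 nM, with an expected range from 14000 nM to 50000 nM.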

Compound 4, half-maximal effective concentration: > 25000 nM
Compound 4: a limit, no number; the forecaster's own chance of this, stated with the estimate: 75%; the middle value lies on the limit itself.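

In this assay compound 4 gives > 25000 nM, a limit of the assay and not a number. The steps to compound 4 from compound 1 and from compound 2 therefore cannot be read. The compounds shown leave open whether 3-methylpyridin-2-yl, 4-fluorophenyl and 2-aminophenyl on that nitrogen differ at all in this assay.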